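The compounds below may be only part of what the source reports. "The series", "measured", "known", "first", "only" and "open" are said of these compounds alone.

Values so far in a physicochemical assay for solubility, read by HPLC, in phosphate buffer, at pH 6.5; on this read-out higher numbers stand for higher solubility and lower numbers for lower solubility
- compound 1 `COC(=O)C1=C(CN2CCOCC2=O)NC(c2nccs2)=NC1(C)c1ccc(F)cc1` gives 440 ug/mL as its value
- compound 2 `COC(=O)C1=C(CN2CCC(O)C2)NC(c2nccs2)=NC1(C)c1ccc(F)cc1` gives 503 ug/mL as its value
- compound 3 `COC(=O)C1=C(CN2CCCS2(=O)=O)NC(c2nccs2)=NC1(C)c1ccc(F)cc1` has no value yet

Among the compounds with values here, compound 2 and compound 1 are the only two compounds measured, and their numbers lie within the scatter of each other, so neither can be ranked above the other. Compound 3 differs from compound 2 by one change, a group of 7 heavy atoms (3 carbon, 1 nitrogen, 2 oxygen, 1 sulfur; one five-membered non-aromatic ring with 2 hetero atoms) in place of a group of 6 heavy atoms (4 carbon, 1 nitrogen, 1 oxygen; one five-membered non-aromatic ring with 1 hetero atom), on a saturated chain carbon bound to a double-bonded ring carbon and the rest of the structure stays the same.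

Within the data shown here, only one measured step bears on this place, a 1.1-fold higher number from compound 1 to compound 2 (0.06 log units; within the scatter) and it shows no change beyond the scatter. Among the measured compounds shown here, no measured step brings in the group that enters here, so this evidence is indirect and the range has to stay wide. The expectation rests on compound 2 at 503 ug/mL and on that single step, and no shift beyond the scatter is expected in this assay in either direction. The expected step is a 1.3-fold lower number from compound 2 to compound 3 (0.10 log units; within the scatter) and it would stay within the scatter. For compound 3 the estimated value is 400 ug/mL with an expected range from 150 ug/mL to 900 ug/mL in this measurement.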

Compound 3, solubility: 125 ug/mL
Compound 3: the middle estimate sits 3.2-fold (0.51 log units) above what was measured; measured number outside the range, below it.
By their numbers in this assay, from the lowest: compound 3; then compounds 1 and 2 (each within the scatter of the next).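

In this assay, the substituent on a saturated chain carbon bound to a double-bonded ring carbon proves able to move the number beyond the scatter, which the exchange of 3-oxomorpholin-4-yl for 3-hydroxypyrrolidin-1-yl had not shown. The new group gives a 4.0-fold lower number from compound 2 to compound 3 (0.60 log units; beyond the scatter) and, against the six-membered group, a 3.5-fold lower number from compound 1 to compound 3 (0.55 log units; beyond the scatter) so it stands apart from both earlier groups, while those two remain within the scatter of each other. Compared with 3-hydroxypyrrolidin-1-yl, the entering group also has a five-membered non-aromatic ring and the same count of hydrogen-bond acceptors, but it has no hydrogen-bond donor, a second ring hetero atom and two double bonds outside aromatic rings, and no measurement here gives a reason for the lower number.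

As far as these compounds go, these three compounds do not separate the counted differences, so it stays open which of them goes with the step. From the compounds shown here alone, it also remains open where this assay would place a piperazine, a carboxylic acid or a simple open-chain methanesulfonamide carried on the same chain carbon, with the rest of the structure unchanged.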